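The source may hold more compounds than are shown below. What is called first, only, known or untested is meant among the compounds shown, and "the series" means these compounds.

The three measured compounds, with their results in a functional assay on LNCaP cells (Homo sapiens) for antiproliferative activity, read by MTT assay, with a stated time of 96 h; on this read-out lower numbers stand for stronger inhibition and higher numbers for weaker inhibition:

compound 1, `CC(CSc1ccc(F)cc1)C(=O)Nc1ccc(C#N)c(C(F)(F)F)c1`, gives 8690 nM
compound 2, `CC(CSc1ccc(F)cc1)C(=O)Nc1ccc([N+](=O)[O-])c(C(F)(F)F)c1`, gives 27200 nM
compound 3, `CC(CS(=O)(=O)c1ccc(F)cc1)C(=O)Nc1ccc(C#N)c(C(F)(F)F)c1`, gives 115000 nM

Compound 1 and compound 2 differ in one place: nitro in place of cyano on an aromatic carbon. That change produced a 3.1-fold higher number from compound 1 to compound 2 (0.50 log units; beyond the scatter), a step beyond the usual scatter. Compound 3 shares the cyano-bearing ring of compound 1 but differs from it elsewhere; the difference between the two cores is not broken down here. Of the three, compound 3 gives the highest number, and its gap to each of the other two lies beyond the scatter.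

Compound 4, `CC(CS(=O)(=O)c1ccc(F)cc1)C(=O)Nc1ccc([N+](=O)[O-])c(C(F)(F)F)c1`, is not yet measured. It stands to compound 3 as compound 2 stands to compound 1: nitro in place of cyano on an aromatic carbon. The two place descriptions match word for word, so this is the same change made on the core of compound 3 instead of the core of compound 1.

In this assay, going by the values given here, the expected step is a 2.8-fold higher number from compound 3 to compound 4 (0.44 log units; beyond the scatter), set beside the measured 3.1-fold higher number from compound 1 to compound 2 (0.50 log units; beyond the scatter); it rests on the single precedent in which the change raised the number, because compound 2 gave 27200 nM against compound 1 at 8690 nM. Since compound 3 already gives 115000 nM, compound 4 is expected near 320000 nM, within roughly 120000 nM to 850000 nM.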

Compound 4, half-maximal inhibitory concentration: 2670 nM
For compound 4 the middle estimate is 120-fold (2.08 log units) above the measured one, outside the stated range (below it).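

In this assay, putting nitro in place of cyano on the core of compound 3 gave a 43-fold lower number from compound 3 to compound 4 (1.63 log units; beyond the scatter), which runs opposite to the step seen on the core of compound 1, and the two results clearly disagree: the same change on two cores in this assay, a 3.1-fold higher number (0.50 log units; beyond the scatter) from compound 1 to compound 2 and a 43-fold lower number (1.63 log units; beyond the scatter) from compound 3 to compound 4, 130-fold (2.13 log units) apart, beyond the scatter of two such steps. This shows that, among the compounds shown, the change cannot be carried from one core to another as a fixed step, since neither its direction nor its size held across the two cores. Going by these compounds alone, it does not show why the two cores part ways, and with only one pair on each core it cannot say which result is more typical of the series or whether either would be repeated on a further core.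

The compounds shown leave open how the same change would behave on a core carrying a sulfoxide or an ether oxygen at the place where compound 1 and compound 3 differ, which could show whether the reversal is confined to the core of compound 3. They also leave open whether an amine or a carboxylic acid in the place of cyano and nitro would follow either pattern on these two cores.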